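A few compounds are considered here, and "the series" means these few. Any claim that something is new, unique, unknown or untested is made for them only; others in the source may bear on it.

Working notes on the series in a functional assay for inhibition of sodium/hydrogen exchanger (Oryctolagus cuniculus); a lower number here means a stronger inhibitor, a higher number a weaker inhibitor.

Of the compounds shown here, three sharing the acylguanidine and methylsulfonyl core have been measured. Compound 1 `Cc1ccc(-c2ccc(C(=O)N=C(N)N)cc2S(C)(=O)=O)cc1` gives 100 nM. For the measured compounds named here, compound 2 `CS(=O)(=O)c1cc(C(=O)N=C(N)N)ccc1-n1ccnc1` gives 150 nM; the only single-point step so far, a 1.5-fold higher number from compound 1 to compound 2 (0.18 log units; within the scatter), is the exchange of a pair of aryl substituents and does not move the number meaningfully. Compound 3 `Cc1cc(Oc2cncc(Cl)c2)c(S(C)(=O)=O)cc1C(=O)N=C(N)N` gives 14 nM, the lowest of the three numbers, and its gap to compound 1 and to compound 2 is in each case beyond the usual scatter, so compound 3 stands apart as the strongest inhibitor measured.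

The next compound, compound 4 `CS(=O)(=O)c1cc(C(=O)N=C(N)N)ccc1Oc1cncc(Cl)c1`, keeps the (5-chloropyridin-3-yl)oxy and methylsulfonyl groups of compound 3 and differs only by hydrogen in place of methyl on an aromatic carbon. Going by the values given here, no measured step in this set removes a methyl from the core ring; the step from compound 1 to compound 2 concerns a different position and a different kind of group, so it offers no guide. With nothing in the data to show that the methyl carries the potency of compound 3, the expectation for compound 4 is a step of a 2.0-fold higher number from compound 3 to compound 4 (0.30 log units; within the scatter) in this assay, toward a somewhat higher number but not clearly beyond the scatter. Compound 4 is therefore estimated at 28 nM, with a range from 9 nM to 90 nM.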

Compound 4, half-maximal inhibitory concentration: 75 nM
Beside the measured number, compound 4's estimate is 2.7-fold (0.43 log units) below it, and the stated range covers the measured number.
By their numbers in this assay, from the lowest: compound 3; then compounds 4, 1 and 2 (each within the scatter of the next).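

In this assay, for the compounds shown here, the methyl on the aromatic carbon para to a methylsulfonyl group proves to count for more than any earlier comparison could show: with hydrogen in its place there is a 5.4-fold higher number from compound 3 to compound 4 (0.73 log units; beyond the scatter), the first single-place step to lie beyond the scatter. Without that methyl, the (5-chloropyridin-3-yl)oxy group does not set the compound apart, with a 2.0-fold lower number from compound 2 to compound 4 (0.30 log units; within the scatter) and a 1.3-fold lower number from compound 1 to compound 4 (0.12 log units; within the scatter), so the three compounds carrying hydrogen on this carbon read alike despite their different aryl or heteroaryl groups, and the (5-chloropyridin-3-yl)oxy group alone does not reproduce the number of compound 3. Nothing in the data explains why the methyl step is this large.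

As far as these compounds go, the methyl step is seen only alongside the (5-chloropyridin-3-yl)oxy group, so it remains open whether methyl on this carbon would have a similar effect alongside 4-methylphenyl or 1H-imidazol-1-yl. From the compounds shown here alone, it also remains open how an ethyl, a methoxy or a chlorine on the same carbon would compare with methyl and with hydrogen.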